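Methylating the Amine of Compound 2

The source may hold more compounds than are shown below. What is called first, only, known or untested is meant among the compounds shown, and "the series" means these compounds.

Compound 2 `CCn1ccc(N2C[C@H](CN)OC2=O)c1` gives 25000 nM in an assay for inhibition of Amine oxidase [flavin-containing] B (Bos taurus), read by fluorescence, with a stated time of 30 min (on this read-out lower numbers stand for stronger inhibition and higher numbers for weaker inhibition), the highest of the two numbers recorded; its nearest neighbour, compound 1 `CCn1ccc(N2C[C@H](CO)OC2=O)c1`, gives 300 nM. For the measured compounds named here, the only measured step is an 83-fold higher number from compound 1 to compound 2 (1.92 log units; beyond the scatter), which covers amino in place of hydroxy on a saturated chain carbon bound to a saturated ring carbon. Compound 3 `CCn1ccc(N2C[C@H](CNC)OC2=O)c1` differs from compound 2 by methyl in place of hydrogen on an amine nitrogen, that is, amino to methylamino. Going by the values given here, no measured step touches a change on the amine nitrogen itself; the step from compound 1 to compound 2 bears on it only by showing that this chain end matters greatly. With nothing to indicate a direction, the change is expected to leave the number roughly where it is. For compound 3 the expected step is no change at the digits printed from compound 2 to compound 3 (within the scatter), within the scatter. The estimate for compound 3 in this assay is 25000 nM, ranging from 7000 nM to 90000 nM.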

Compound 3, inhibition constant: 18000 nM
Estimate against measurement, compound 3: 1.4-fold (0.14 log units) above; low and high end bracket the measured number.
By their numbers in this assay, from the lowest: compound 1; then compounds 3 and 2 (each within the scatter of the next).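

In this assay, for the compounds shown here, the first measured change on the amine nitrogen itself, methyl in place of hydrogen, gives a 1.4-fold lower number from compound 2 to compound 3 (0.14 log units; within the scatter), so this single methyl does not separate the two amines. Methylamino in place of hydroxy gives a 60-fold higher number from compound 1 to compound 3 (1.78 log units; beyond the scatter), so compound 3, like compound 2, stays far from compound 1, and this methyl does not close the gap opened by replacing the hydroxy group at this chain end. No supporting evidence accompanies these numbers on why the chain end is so sensitive.

The compounds shown leave open whether a dimethylamino group or an ethylamino group would behave like the methylamino group on the same chain carbon. They also leave open whether a methoxy group, which keeps oxygen at this chain end, would stay close to compound 1.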